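A Nitrile Replaces a Nitro Group on the Sulfonyl

The source may report more compounds than this note shows. Statements on the series, on what has been measured and on what is new or still open speak of the compounds shown alone.

Of the compounds shown here, three sharing one core have been tested in an ADME assay on BJ cells (Homo sapiens) for antiproliferative activity, with a stated time of 72 h; on this read-out higher numbers stand for an effect only at larger amounts of compound and lower numbers for an effect already at smaller amounts. Compound 1 `COc1ccc(-c2cc(=O)c3c(OC)cc(OC)cc3n2Cc2ccccc2)cc1` carries a benzyl group on the ring nitrogen. In this assay compound 1 gives > 34400 nM, which is a limit of the assay rather than a number (the limit of > 34400 nM in this assay, at which 1 of the 3 values shown sits). Compound 2 `COc1ccc(-c2cc(=O)c3c(OC)cc(OC)cc3n2S(=O)(=O)c2ccc([N+](=O)[O-])cc2)cc1` carries a 4-nitrophenyl group on a sulfonyl sulfur bound to that nitrogen. In this assay compound 2 gives > 29300 nM, again a limit (the limit of > 29300 nM in this assay, at which 1 of the 3 values shown sits). Compound 3 `COc1ccc(-c2cc(=O)c3c(OC)cc(OC)cc3n2S(=O)(=O)c2ccc(C)c([N+](=O)[O-])c2)cc1` carries a 4-methyl-3-nitrophenyl group on the same sulfonyl sulfur. In this assay compound 3 gives > 51700 nM, also a limit (the limit of > 51700 nM in this assay, at which 1 of the 3 values shown sits). The step that the two limits leave unreadable from compound 2 to compound 3 therefore cannot be read, and compound 3 stands at a limit like the other two.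

Compound 4 `COc1ccc(-c2cc(=O)c3c(OC)cc(OC)cc3n2S(=O)(=O)c2ccc(C#N)cc2)cc1` differs from compound 3 by 4-cyanophenyl in place of 4-methyl-3-nitrophenyl on a sulfonyl sulfur. Among the measured compounds shown here, no measured step has a readable size, so no shift beyond the scatter can be foreseen in either direction. Compound 4 is expected to give 50000 nM, estimated within 15000 nM to 150000 nM, most likely again as a limit. The estimated step is an at least 1.0-fold lower number from compound 3 to compound 4 (0.01 log units; that floor lies within the scatter).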

Compound 4, half-maximal effective concentration: > 17200 nM
Compound 4 ended at the assay's limit; the forecaster's own chance of this, stated with the estimate: 85%; the middle value lies beyond the limit too.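

In this assay compound 4 also ends at a limit of the assay, like compound 1, compound 2 and compound 3, so none of the steps from those three to compound 4 can be read. The compounds shown leave open whether, and how far, changing the group on the aromatic nitrogen shifts the read-out.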